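This account rests on a few compounds, and the source may have more. Where it says the series, first, only, none or still open, it means among the compounds named here.

Measured so far:
compound 1, `COc1ccc(-c2nc(SCC(=O)c3sc(-c4ccccc4)nc3C)[nH]c(=O)c2C#N)cc1`: 97.3%
compound 2, `COc1ccc(-c2nc(C)c(C(=O)CSc3nc(-c4cccc(OC)c4)c(C#N)c(=O)[nH]3)s2)cc1`: 71.3%

In a functional assay on U-87MG ATCC cells for antiproliferative activity against U-87 MG (Homo sapiens), read by MTT assay, with a stated time of 48 h, tested at 5 uM (on this read-out lower numbers stand for a stronger effect and higher numbers for a weaker effect at the one concentration tested), compound 2 stands at the lower of the two numbers measured, and its value of 71.3% marks the stronger effect of the pair. Compound 1, whose value in this assay is 97.3%, lies a distance away that is beyond the usual scatter. Among the compounds with values here, no single step between measured compounds that differ in one place has been drawn, so the size of such a step is still open. Compound 3, `COc1cccc(-c2nc(SCC(=O)c3sc(-c4ccccc4)nc3C)[nH]c(=O)c2C#N)c1`, has not yet been measured in this assay. Against compound 2 it shows this change: hydrogen in place of methoxy on an aromatic carbon. With the methoxy gone, a somewhat weaker effect, meaning a higher number in this assay, is expected, though the step may stay within the scatter. The step expected here is a number 10.7 percentage points higher from compound 2 to compound 3 (beyond the scatter). For compound 3 the estimate in this assay is 82%, with a range from 62% to 100%.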

Compound 3, a percentage reported as activity, at one concentration (the size of the read-out at that concentration, not a potency): 99%
The estimate for compound 3 lay 17 percentage points below the measured number; low and high end bracket the measured number.
By their numbers in this assay, from the lowest: compound 2; then compounds 1 and 3 (each within the scatter of the next).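

In this assay, the change from 4-methoxyphenyl to phenyl gives the first step measured at this place (a number 27.7 percentage points higher from compound 2 to compound 3 (beyond the scatter)), so among these compounds the stronger effect goes with the methoxy on this ring. Swapping 4-methoxyphenyl for 3-methoxyphenyl at a second place on the molecule gives a step that stays within the scatter (a number 1.7 percentage points higher from compound 1 to compound 3 (within the scatter)), so these two placements of the methoxy cannot be told apart in this pair. Nothing measured on these compounds explains either result.

On these data alone, at the first place, the comparison covers only methoxy and hydrogen, so it remains open whether ethoxy, fluorine or a dimethylamino group would give a stronger or weaker effect. As far as these compounds go, the read-out also comes from one concentration, so whether these compounds would give a stronger or weaker effect at any other concentration remains open as well.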